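Swapping a Phenyl for Fluoro on an Inactive Ester Scaffold

This account rests on a few compounds, and the source may have more. Where it says the series, first, only, none or still open, it means among the compounds named here.

Compound 3 `CCOC(=O)CCCCCOc1cccc(CN(C(=O)c2ccc(-c3cccc(-c4ccccc4)c3)cc2)C(C)C)c1` is an ethyl ester that has been tested for its effect on cell survival. In an ADME assay on Raji cells (Homo sapiens) for cytotoxicity, read by CellTiter-Glo and resazurin assay, with a stated time of 72 h (a higher number here means that more compound is needed for the effect, a lower number that less compound is needed), compound 3 gives > 26000 nM, and this is a limit of the measurement, not a number. Two relatives stand at the same point. Compound 1 `CC(C)N(Cc1cccc(OCCCCCC(=O)O)c1)C(=O)c1ccc(-c2cccc(-c3ccccc3)c2)cc1` is the matching free acid. In this assay compound 1 gives > 26000 nM, again a limit. Compound 2 `CC(C)N(Cc1cccc(OCCCCCC(=O)O)c1)C(=O)c1ccc(-c2ccc3cc[nH]c3c2)cc1` carries 1H-indol-6-yl where compound 1 carries 3-phenylphenyl. In this assay compound 2 gives > 26000 nM, also a limit. Because all three values sit at the limit of > 26000 nM in this assay, at which 3 of the 3 values shown sit, the steps a step that the two limits leave unreadable from compound 1 to compound 2 and a step that the two limits leave unreadable from compound 1 to compound 3 cannot be read, so neither the ester nor the ring exchange has a measurable size here.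

Compound 4 `CCOC(=O)CCCCCOc1cccc(CN(C(=O)c2ccc(-c3cccc(F)c3)cc2)C(C)C)c1` differs from compound 3 by fluoro in place of phenyl on an aromatic carbon. No measured step among these compounds covers the change from 3-phenylphenyl to 3-fluorophenyl, and every value so far is a limit, so there is nothing to transfer. Compound 4 is therefore expected to give 26000 nM, with a plausible range from 10000 nM to 60000 nM. The expected step of a number no higher from compound 3 to compound 4 (the limit leaves the size open) amounts to no change beyond the scatter, most likely another limit.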

Compound 4, half-maximal effective concentration: > 26000 nM
Compound 4 gave a limit, no number; the forecaster's own chance of this, stated with the estimate: 80%; the middle value lies on the limit itself.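

In this assay compound 4 gives > 26000 nM, which is a limit and not a number. Compound 3 also stands at a limit, so the step from phenyl to fluoro between these two compounds has no readable size: the limit of > 26000 nM in this assay, at which 4 of the 4 values shown sit. The compounds shown leave open at what concentration any of them affects these cells, and whether any of these group exchanges shifts that concentration.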